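Shortening the Chain on a Compound at the Assay Limit

The source may report more compounds than this note shows. Statements on the series, on what has been measured and on what is new or still open speak of the compounds shown alone.

Measured so far:
Compound 1 `CCCC/N=C(\C)c1c(O)c2ccccc2[nH]c1=O`: >= 100000 nM
Compound 2 `CCC/C(=N\Cc1ccccc1)c1c(O)c2ccccc2oc1=O`: >= 100000 nM

The value of compound 1 is a limit of the assay, not a number. The value of compound 2 is likewise a limit. In an assay on isolated protein for inhibition of myosin-2 (Bos taurus), read by spectrophotometry, with a stated time of 24 min (on this read-out lower numbers stand for stronger inhibition and higher numbers for weaker inhibition), compound 2 sits at the limit of >= 100000 nM in this assay, at which 2 of the 2 values shown sit. Compound 3 `CC/C(=N\Cc1ccccc1)c1c(O)c2ccccc2oc1=O` differs from compound 2 by hydrogen in place of methyl on a saturated chain carbon, two bonds along the chain from a carbon with a double bond to nitrogen. Starting from a limit, no step beyond the usual scatter can be foreseen in this assay. Compound 3 is expected to give 100000 nM, with a range from 30000 nM to 300000 nM. The step of a number no higher from compound 2 to compound 3 (the limit leaves the size open) behind this estimate is expected to be none beyond the scatter.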

Compound 3, half-maximal inhibitory concentration: >= 100000 nM
Compound 3 was reported as a limit; the forecaster's own chance of this, stated with the estimate: 85%; the middle value lies on the limit itself.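

Compound 2 and compound 3 are both reported as limits, not numbers, and no step can be read between them. The compounds shown leave open whether propyl to ethyl changes inhibition at all, and how strongly any of them inhibits.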